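A few compounds are considered here, and "the series" means these few. Any claim that something is new, unique, unknown or untested is made for them only; others in the source may bear on it.

Compound 1, `CCN(CC)CCNC(=O)c1ccc(C(CC)(CC)c2ccc(OCC(=O)C(C)(C)C)c(C)c2)n1CC`: 91 nM
Compound 2, `CCn1c(C(=O)NCCCN(C)C)ccc1C(CC)(CC)c1ccc(OCC(=O)C(C)(C)C)c(C)c1`: 96 nM
Compound 3, `CCn1c(C(=O)NCCCN(C)C)ccc1C(CC)(CC)c1ccc(OCC(O)C(C)(C)C)c(C)c1`: 37 nM

All three were tested in an assay on HL-60 cells for agonist activity at vitamin D3 receptor (Homo sapiens), read by microscopy, with a stated time of 96 h; on this read-out higher numbers stand for an effect only at larger amounts of compound and lower numbers for an effect already at smaller amounts. Compound 3 shows the lowest number of the three; compound 1 and compound 2 both give higher numbers beyond the usual scatter, as the step of a 2.6-fold lower number from compound 2 to compound 3 (0.41 log units; beyond the scatter) shows. Compound 4, `CCn1c(C(=O)N(C)CC(=O)O)ccc1C(CC)(CC)c1ccc(OCC(O)C(C)(C)C)c(C)c1`, has not yet been measured. It differs from compound 3 in the group attached to the carbonyl carbon: (carboxymethyl)(methyl)amino in place of (3-(dimethylamino)propyl)amino on a carbonyl carbon. Going by the values given here, the only measured step at this part of the molecule is a 1.1-fold higher number from compound 1 to compound 2 (0.02 log units; within the scatter), a small exchange of one amine for another, and the two numbers lie within the scatter of each other. The change to compound 4 is of a different kind: the whole (3-(dimethylamino)propyl)amino group leaves and a (carboxymethyl)(methyl)amino group enters, so that step gives only weak guidance. The other step, a 2.6-fold lower number from compound 2 to compound 3 (0.41 log units; beyond the scatter), sits at another place in the molecule and does not bear on this exchange. Among the compounds with values here, with no close precedent, a moderate rise in the number is expected for compound 4 in this assay, a 2.2-fold higher number from compound 3 to compound 4 (0.33 log units; beyond the scatter). The estimate for compound 4 is 80 nM, with a range from 25 nM to 300 nM.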

Compound 4, half-maximal effective concentration: 740 nM
Beside the measured number, compound 4's estimate is 9.3-fold (0.97 log units) below it; the measured number lies above the stated range.
By their numbers in this assay, from the lowest: compound 3; then compounds 1 and 2 (each within the scatter of the next); then compound 4.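

In this assay the group on the carbonyl carbon turns out to matter a great deal: putting (carboxymethyl)(methyl)amino in place of (3-(dimethylamino)propyl)amino gives a 20-fold higher number from compound 3 to compound 4 (1.30 log units; beyond the scatter) in this one exchange. Going by these compounds alone, the earlier compounds gave no sign of this, since the only step at this place, a 1.1-fold higher number from compound 1 to compound 2 (0.02 log units; within the scatter), swapped one amine-bearing chain for another and made the position look undemanding. The new step shows that this calm holds only for that narrow exchange and not for every group on the carbonyl carbon, though nothing shown here gives a reason for the rise.

Going by these compounds, whether the rise goes with the carboxylic acid, with the loss of the dimethylamino group or with the methyl on the amide nitrogen stays open, as all three change together in this single step. A methyl ester in place of the carboxylic acid, or a (carboxymethyl)amino group that keeps the amide hydrogen, would help to pull these changes apart.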